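The source may hold more compounds than are shown below. What is called first, only, known or untested is meant among the compounds shown, and "the series" means these compounds.

Measured so far:
compound 1 `O=C(/C=C\Nc1ccc(F)cc1)c1cn(-c2ccccc2)nc1-c1ccc(F)cc1`, > 50000 nM
compound 2 `COc1ccc(N/C=C\C(=O)c2cn(-c3ccccc3)nc2-c2ccc(Cl)cc2)cc1`, 30800 nM
compound 3 `COc1ccc(-c2nn(-c3ccccc3)cc2C(=O)/C=C\Nc2ccc(F)cc2)cc1`, 8910 nM

In an ADME assay on HaCaT cells (Homo sapiens) for antiproliferative activity, read by MTT assay, with a stated time of 48 h (on this read-out higher numbers stand for weaker inhibition and lower numbers for stronger inhibition), compound 3 gives 8910 nM, the lowest number among the three; compound 2 gives 30800 nM. The value of compound 1 is a limit of this assay (the limit of > 50000 nM in this assay, at which 1 of the 3 values shown sits). Compound 4 `COc1ccc(N/C=C\C(=O)c2cn(-c3ccccc3)nc2-c2ccc(OC)cc2)cc1` differs from compound 3 by methoxy in place of fluoro on an aromatic carbon, read one bond further out as (4-fluorophenyl)amino becoming (4-methoxyphenyl)amino. Among the measured compounds shown here, the only measured step of the same exchange, at another site of the shared core, is an at least 5.6-fold lower number from compound 1 to compound 3 (0.74 log units; beyond the scatter). For the measured compounds named here, compound 2 carries the methoxy on the amino-bearing ring but with chloro elsewhere, so the pair with compound 3 gives no single-change step. A modest decrease is expected, a 1.8-fold lower number from compound 3 to compound 4 (0.25 log units; within the scatter). Compound 4 is estimated at 5000 nM, between 2000 nM and 20000 nM.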

Compound 4, half-maximal inhibitory concentration: > 50000 nM
Compound 4: a limit, no number; the forecaster's own chance of this, stated with the estimate: 5%; at least 10-fold (1.00 log units) between middle value and limit.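

In this assay, methoxy in place of fluoro at the (4-fluorophenyl)amino position gives an at least 5.6-fold higher number from compound 3 to compound 4 (0.74 log units; beyond the scatter), against an at least 5.6-fold lower number from compound 1 to compound 3 (0.74 log units; beyond the scatter) at the other site, so the same exchange moves the number in opposite directions at the two sites. Methoxy in place of chloro gives an at least 1.6-fold higher number from compound 2 to compound 4 (0.21 log units; that floor lies within the scatter), which sets no firm order between these two compounds. Compound 4 gives a limit, not a number: the limit of > 50000 nM in this assay, at which 2 of the 4 values shown sit.

Going by these compounds, how far past that limit compound 4 lies remains open. Also open, on these data alone, is whether an amine or a carboxylic acid in place of fluoro on the amino-bearing ring of compound 3 would keep its number.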